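Swapping the aryl ketone of compound 1 for a methyl ester

The source may report more compounds than this note shows. Statements on the series, on what has been measured and on what is new or still open speak of the compounds shown alone.

The shared core carries a benzhydryl ester and an exocyclic double bond bearing a carbonyl substituent. Compound 1 `CC1(C)S[C@@H]2/C(=C\C(=O)c3ccc(C(F)(F)F)cc3)C(=O)N2[C@H]1C(=O)OC(c1ccccc1)c1ccccc1` was tested in a functional assay on A-375 cells (Homo sapiens) for cytotoxicity, read by MTT assay, with a stated time of 48 h (on this read-out lower numbers stand for stronger inhibition and higher numbers for weaker inhibition), where compound 1 gives 26700 nM. For the measured compounds named here, compound 2 `CC1(C)[C@H](C(=O)OC(c2ccccc2)c2ccccc2)N2C(=O)/C(=C/C(=O)c3ccc([N+](=O)[O-])cc3)[C@H]2[S+]1[O-]`, which differs in several places, is the only other measured compound; in this assay compound 2 gives 48200 nM, and the gap between the two numbers lies within the scatter, so neither can be ranked against the other.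

Compound 3 `COC(=O)/C=C1/C(=O)N2[C@@H]1SC(C)(C)[C@@H]2C(=O)OC(c1ccccc1)c1ccccc1` is unmeasured. Its difference from compound 1 is methoxy in place of 4-(trifluoromethyl)phenyl on a carbonyl carbon. Going by the values given here, no step between measured compounds matches this change, so there is no direct precedent. Because compound 1 gives 26700 nM, already a weak number, the account expects a modest step upward from compound 1 to compound 3 of a 2.1-fold higher number from compound 1 to compound 3 (0.31 log units; beyond the scatter), toward weaker inhibition. Compound 3 is estimated at 55000 nM, with a range from 20000 nM to 150000 nM.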

Compound 3, half-maximal inhibitory concentration: 24600 nM
Compound 3: the middle estimate sits 2.2-fold (0.35 log units) above what was measured, within the range that was stated.
By their numbers in this assay, from the lowest: compounds 3, 1 and 2 (each within the scatter of the next).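

Exchanging 4-(trifluoromethyl)phenyl for methoxy on a carbonyl carbon gives a 1.1-fold lower number from compound 1 to compound 3 (0.04 log units; within the scatter) in this assay. For the compounds shown here, this is the first single-place step, and it shows that, between these two groups, the aromatic ring on this carbonyl carbon can be lost without the number moving beyond the scatter. An ester and an aryl ketone therefore cannot be told apart here, and nothing on hand explains that result. The compounds shown leave open whether an amine at this carbonyl carbon, giving an amide, or a longer chain such as butoxy in place of methoxy, would separate from compound 1 in this assay. They also leave open what a free carboxylic acid would do in place of the benzhydryl ester that all three compounds carry.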